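Series notes: stepwise methoxy additions and cell growth

This account rests on a few compounds, and the source may have more. Where it says the series, first, only, none or still open, it means among the compounds named here.

Three members of the series have so far been measured in a functional assay on SK-MEL-28 cells (Homo sapiens) for cytotoxicity, read by sulforhodamine B assay, with a stated time of 48 h, tested at 10 uM; on this read-out higher numbers stand for a weaker effect at the one concentration tested and lower numbers for a stronger effect. Compound 1 `COc1ccc(-c2cc(/C=C/C(=O)c3cc(OC)c(OC)c(OC)c3)[nH]n2)cc1OC` gives -49%, and compound 2 `COc1ccc(C(=O)/C=C/c2cc(-c3cc(OC)c(OC)c(OC)c3)n[nH]2)cc1` gives -55%. Compound 3 `COc1ccc(C(=O)/C=C/c2cc(-c3cc(OC)c(OC)c(OC)c3)n[nH]2)cc1OC` gives -88%, the lowest of the three numbers; its separation from compound 2 and from compound 1 lies beyond the scatter in both cases. Among the compounds with values here, the only single-point step among the measured compounds is a number 33 percentage points lower from compound 2 to compound 3 (beyond the scatter), a large move toward a stronger effect.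

Compound 4 `COc1cc(C(=O)/C=C/c2cc(-c3cc(OC)c(OC)c(OC)c3)n[nH]2)cc(OC)c1OC` has not been measured in this assay. Relative to compound 3 the change is methoxy in place of hydrogen on an aromatic carbon; the entering group sits ortho to a methoxy group and meta to a methoxy group. Within the data shown here, the step from compound 2 to compound 3 is the one measured change of the same kind and it bears directly on this one, but compound 3 already gives -88%, which leaves little room for a further drop of that size. The step from compound 3 to compound 4 is therefore expected to be a number 2 percentage points lower from compound 3 to compound 4 (within the scatter), at most modest and toward a stronger effect, likely within the scatter. Compound 4 is estimated at -90%, with a range from -100% to -70%.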

Compound 4, a percentage reported as activity, at one concentration (the size of the read-out at that concentration, not a potency): -92%
Compound 4: middle estimate off by 2 percentage points, on the high side, and the stated range covers the measured number.
By their numbers in this assay, from the lowest: compounds 4 and 3 (each within the scatter of the next); then compounds 2 and 1 (each within the scatter of the next).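

On the ring that already carries methoxy groups, methoxy in place of hydrogen at the carbon ortho to a methoxy group and meta to a methoxy group gives, in this assay, a number 4 percentage points lower from compound 3 to compound 4 (within the scatter), so the large move seen for this kind of change does not appear at this position. The same kind of change on the core of compound 1 gives a number 43 percentage points lower from compound 1 to compound 4 (beyond the scatter), so the outcome of adding a methoxy depends on where it enters and on what the ring and core already carry, and compound 3 and compound 4 cannot be told apart on this read-out. The two large steps of this kind agree with each other, which means a large move is not confined to a single core: the same change on two cores in this assay, a number 33 percentage points lower (beyond the scatter) from compound 2 to compound 3 and a number 43 percentage points lower (beyond the scatter) from compound 1 to compound 4, 10 percentage points apart, within the scatter of two such steps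

The compounds shown leave open whether anything other than methoxy at this position, such as a hydroxy group, an amine or a carboxylic acid, would separate from compound 3. They also leave open how compound 3 and compound 4 compare in potency, since a read-out at one concentration does not give a potency.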